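A few compounds are considered here, and "the series" means these few. Any claim that something is new, unique, unknown or untested is made for them only; others in the source may bear on it.

Compound 1 `N#CC1(c2cc(CCO)cc(-c3ccnc4[nH]nc(C(F)(F)F)c34)c2)CC1` is one of three close analogues sharing a core, and in an assay on isolated protein for inhibition of protein kinase C epsilon type (Homo sapiens), read by coupled enzyme assay (on this read-out lower numbers stand for stronger inhibition and higher numbers for weaker inhibition), compound 1 gives 25 nM. Its number is the lowest of the three, though compound 2 `C[C@@H](O)Cc1cc(-c2ccnc3[nH]nc(C(F)(F)F)c23)cc(C2(C#N)CC2)c1`, which in this assay gives 34 nM, sits at a 1.4-fold higher number from compound 1 to compound 2 (0.13 log units; within the scatter), so the two cannot be ordered. Compound 3 `COCCc1cc(-c2ccnc3[nH]nc(C(F)(F)F)c23)cc(C2(C#N)CC2)c1`, which in this assay gives 145 nM, stands at a 5.8-fold higher number from compound 1 to compound 3 (0.76 log units; beyond the scatter) and at a 4.3-fold higher number from compound 2 to compound 3 (0.63 log units; beyond the scatter).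

Compound 4 `N#CC1(c2cc(CCF)cc(-c3ccnc4[nH]nc(C(F)(F)F)c34)c2)CC1` has not yet been measured. It differs from compound 1 in one place: fluoro in place of hydroxy on a saturated chain carbon, two bonds along the chain from an aromatic carbon. The step that bears most directly on this is the one in which the hydroxy of compound 1 is capped, a 5.8-fold higher number from compound 1 to compound 3 (0.76 log units; beyond the scatter), with the related 4.3-fold higher number from compound 2 to compound 3 (0.63 log units; beyond the scatter) pointing the same way. Both involve the loss of the hydroxy, as does the change to compound 4. A modest weakening is therefore expected, of about a 4.0-fold higher number from compound 1 to compound 4 (0.60 log units; beyond the scatter), and compound 4 is estimated to give 100 nM in this assay, within a range from 40 nM to 300 nM.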

Compound 4, inhibition constant: 90 nM
The estimate for compound 4 lay 1.1-fold (0.05 log units) above the measured number; measured number inside the range.
By their numbers in this assay, from the lowest: compounds 1 and 2 (each within the scatter of the next); then compounds 4 and 3 (each within the scatter of the next).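

Fluoro in place of hydroxy on this saturated chain carbon, two bonds along the chain from an aromatic carbon, raises the number (a 3.6-fold higher number from compound 1 to compound 4 (0.56 log units; beyond the scatter)), and the same holds against compound 2 (a 2.6-fold higher number from compound 2 to compound 4 (0.42 log units; beyond the scatter)). Capping was thus not the only change at this place to weaken inhibition: among these four compounds, both that carry a free hydroxy on this chain, compound 1 and compound 2, sit beyond the scatter below both that do not, compound 3 and compound 4, and none goes against this. Fluoro and methoxy cannot be ordered here (a 1.6-fold lower number from compound 3 to compound 4 (0.21 log units; within the scatter)).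

Nothing shown bears on why the free hydroxy goes with the lower numbers. Going by these compounds, whether an amine, a carboxylic acid or a longer chain ending in hydroxy at this place would match the 2-hydroxyethyl of compound 1 stays open.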